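Furan-3-yl to thiophen-3-yl on compound 2

The source may hold more compounds than are shown below. What is called first, only, known or untested is meant among the compounds shown, and "the series" means these compounds.

Compound 1 `CNc1ncnc2c1c(-c1ccsc1)cn2[C@@H]1O[C@H](CO)[C@@H](O)[C@H]1O`: > 20000 nM (a limit)
Compound 2 `CN(C)c1ncnc2c1c(-c1ccoc1)cn2[C@@H]1O[C@H](CO)[C@@H](O)[C@H]1O`: 9060 nM

Going by the values given here, in a functional assay on HeLa S3 cells (Homo sapiens) for antiproliferative activity, read by XTT assay, with a stated time of 72 h (a lower number here means a stronger inhibitor, a higher number a weaker inhibitor), compound 2 gives 9060 nM, the only actual number so far.

Compound 1 reports > 20000 nM, which is a limit of the assay and not a number.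

Compound 3 `CN(C)c1ncnc2c1c(-c1ccsc1)cn2[C@@H]1O[C@H](CO)[C@@H](O)[C@H]1O` keeps everything in compound 2 except one group, with thiophen-3-yl in place of furan-3-yl on an aromatic carbon. Among the compounds with values here, no measured pair shows this swap alone. In this assay, a step no larger than the usual scatter is expected, leaning slightly toward weaker inhibition, since compound 1, which also carries thiophen-3-yl, reports the limit > 20000 nM. The expected change is a 1.3-fold higher number from compound 2 to compound 3 (0.12 log units; within the scatter). The estimate for compound 3 is 12000 nM, with an expected range from 4500 nM to 20000 nM.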

Compound 3, half-maximal inhibitory concentration: > 15000 nM
Compound 3: a limit, no number; the forecaster's own chance of this, stated with the estimate: 35%; middle value at least 1.2-fold (0.09 log units) from the limit.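

Going by these compounds alone, putting thiophen-3-yl in place of furan-3-yl on this aromatic carbon gives an at least 1.6-fold higher number from compound 2 to compound 3 (0.21 log units; that floor lies within the scatter) in this assay, the first direct look at this swap, though only the lower end of its size is known. The step from compound 1 to compound 3, methyl in place of hydrogen on a nitrogen, cannot be read, since both ends of it are limits. Compound 3 itself reports a limit of the assay and not a number: the limit of > 15000 nM in this assay, at which 1 of the 3 values shown sits.

What the compounds shown leave open is how far above compound 2 the true value of compound 3 lies, and whether the methyl groups on the nitrogen matter at all. A phenyl ring, an amine or a longer chain on this aromatic carbon would show whether anything other than a five-membered aromatic ring changes the picture.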